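The compounds below may be only part of what the source reports. "The series", "measured", "known", "first", "only" and "open" are said of these compounds alone.

In a functional assay on NCI-H522 cells (Homo sapiens) for cytotoxicity, read by sulforhodamine B assay, with a stated time of 48 h, tested at 10 uM (on this read-out lower numbers stand for a stronger effect and higher numbers for a weaker effect at the one concentration tested), compound 1 `COc1ccc(-c2cc(/C=C/C(=O)c3ccc(N)cc3)[nH]n2)cc1` gives -70%. Going by the values given here, the only other measured compound, compound 2 `COc1cc(-c2cc(/C=C/C(=O)c3ccc(F)c(F)c3)[nH]n2)cc(OC)c1OC`, is built differently in more than one place, so no single change links the two; in this assay compound 2 gives -38%. Among the compounds with values here, that number lies above the one for compound 1 by more than the usual scatter, so of the two numbers compound 1 stands lowest, which on this read-out means the stronger effect at the single concentration tested.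

Compound 3 `COc1ccc(-c2cc(/C=C/C(=O)c3ccc(N)cc3)[nH]n2)cc1OC` has not yet been measured. It differs from compound 1 in one place: methoxy in place of hydrogen on an aromatic carbon. Within the data shown here, no measured pair shows what this kind of change does here, so the expectation can rest only on the two values that exist. Because compound 1 gives -70%, compound 3 is expected to stay near it, with at most a modest move toward a weaker effect. The expected step in this assay is a number 12 percentage points higher from compound 1 to compound 3 (beyond the scatter). Compound 3 is therefore estimated at -58%, with a range from -90% to -25%.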

Compound 3, a percentage reported as activity, at one concentration (the size of the read-out at that concentration, not a potency): -84%
Beside the measured number, compound 3's estimate is 26 percentage points above it; measured number inside the range.
By their numbers in this assay, from the lowest: compound 3; then compound 1; then compound 2.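

In this assay, methoxy in place of hydrogen on an aromatic carbon gives a number 14 percentage points lower from compound 1 to compound 3 (beyond the scatter), and on this read-out a lower number means a stronger effect at the one concentration tested. Going by these compounds alone, this is the first direct view of this position, ortho to a methoxy group and meta to a large group: the added methoxy does not weaken the effect here but strengthens it modestly, a finding that rests on this single pair. No measurement shown explains why the number falls, so the step stands as an observation without a known cause.

The compounds shown leave open whether the gain belongs to methoxy itself or whether another group at this position, such as hydroxy, ethoxy or chlorine, would give a similar step. They also leave open whether the same change would act in the same direction on a compound with a different substituent in place of the amine, since one pair cannot establish a general pattern.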